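This account rests on a few compounds, and the source may have more. Where it says the series, first, only, none or still open, it means among the compounds named here.

Working notes on a small set of pyrimidine-type amines tested for inhibition of deoxycytidine kinase from rat. Compound 1 `CCCn1ccc(N)nc1=O` is the weakest of the two measured: in an assay on isolated protein for inhibition of deoxycytidine kinase (Rattus norvegicus) (on this read-out higher numbers stand for weaker inhibition and lower numbers for stronger inhibition), compound 1 gives 12000000 nM. Compound 2 `CCCCCCCCOc1nccc(N)n1` carries the lower of the two numbers; in this assay compound 2 gives 1000000 nM, and the gap between compound 1 and compound 2 lies beyond the usual scatter. Going by the values given here, no step between two measured compounds that differ in a single place is available, so there is nothing yet to say about how chain length moves the read-out.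

Compound 3 `CCCCCOc1nccc(N)n1` follows from compound 2 by one change: hydrogen in place of propyl on a saturated chain carbon, five bonds along the chain from an oxygen on an aromatic ring. Among the compounds with values here, with no measured step of this kind to lean on, the expectation is a step from compound 2 to compound 3 of a 3.0-fold higher number from compound 2 to compound 3 (0.48 log units; beyond the scatter) toward weaker inhibition. For compound 3 the estimated value in this assay is 3000000 nM, with a range from 1000000 nM to 10000000 nM.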

Compound 3, half-maximal inhibitory concentration: 7000000 nM
Compound 3: the middle estimate sits 2.3-fold (0.37 log units) below what was measured; the measured number falls inside the stated range.
By their numbers in this assay, from the lowest: compound 2; then compounds 3 and 1 (each within the scatter of the next).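

In this assay the series now has its first step at a single place, a 7.0-fold higher number from compound 2 to compound 3 (0.85 log units; beyond the scatter), so hydrogen in place of propyl on this saturated chain carbon moves the read-out toward weaker inhibition. This gives a direction for one change at one position, read from a single pair, and does not yet amount to a trend with chain length. Nothing on hand accounts for the size or direction of this step.

Open, on these data alone, is whether a longer chain than that of compound 2 would bring a further move toward stronger inhibition, and whether the numbers for chains of intermediate length fall evenly between compound 3 and compound 2. Also open, as far as these compounds go, is how an amine or a carboxylic acid in place of propyl at this carbon would read.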